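Working notes: from compound 3 to compound 4

The source may report more compounds than this note shows. Statements on the series, on what has been measured and on what is new or still open speak of the compounds shown alone.

In a functional assay on HeLa cells (Homo sapiens) for cytotoxicity, read by MTT assay (a lower number here means a stronger inhibitor, a higher number a weaker inhibitor), compound 1 `CC(=O)OCCC(=O)O[C@H](CC=C(C)C)C1=CC(=O)c2c(O)ccc(O)c2C1=O` gives 17300 nM and compound 3 `CC(C)=CC[C@@H](OC(=O)CC(O)c1ccccc1)C1=CC(=O)c2c(O)ccc(O)c2C1=O` gives 44500 nM as the higher of the two numbers. Compound 2 `CCCCCCC(C)(O)CC(=O)O[C@H](CC=C(C)C)C1=CC(=O)c2c(O)ccc(O)c2C1=O` reads > 100000 nM as a limit of the assay, not a number. Compound 4 `CC[C@@](C)(O)CC(=O)O[C@H](CC=C(C)C)C1=CC(=O)c2c(O)ccc(O)c2C1=O` is unmeasured, and its change is 1-hydroxy-1-methylpropyl in place of hydroxy(phenyl)methyl on a saturated chain carbon bound to a carbonyl carbon at this place. Among the measured compounds shown here, two steps bear on it: a 2.6-fold higher number from compound 1 to compound 3 (0.41 log units; beyond the scatter) and an at least 2.2-fold lower number from compound 2 to compound 3 (0.35 log units; beyond the scatter) are both beyond the scatter. Compound 2 carries the longer 1-hydroxy-1-methylheptyl, and an at least 5.7-fold higher number from compound 1 to compound 2 (0.76 log units; beyond the scatter) hints at upward risk. The expected change is a 1.1-fold higher number from compound 3 to compound 4 (0.05 log units; within the scatter) and no more than the scatter. For compound 4 the estimated value is 50000 nM (expected range 20000 nM to 100000 nM) in this assay here.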

Compound 4, half-maximal inhibitory concentration: 17900 nM
Compound 4: middle estimate off by 2.8-fold (0.45 log units), on the high side; the measured number lies below the stated range.
By their numbers in this assay, from the lowest: compounds 1 and 4 (each within the scatter of the next); then compound 3. At a limit, above all of these: compound 2.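

In this assay, 1-hydroxy-1-methylpropyl on a saturated chain carbon bound to a carbonyl carbon gives a lower number than hydroxy(phenyl)methyl, with a 2.5-fold lower number from compound 3 to compound 4 (0.40 log units; beyond the scatter). Against acetoxymethyl, the same group shows a 1.0-fold higher number from compound 1 to compound 4 (0.01 log units; within the scatter), so two unlike groups read alike at this place. Compound 2 reads at a limit of the assay, not a number, and an at least 5.5-fold lower number from compound 2 to compound 4 (0.74 log units; beyond the scatter) ties the loss in this pair to the longer chain rather than to the 1-hydroxy-1-methyl branch.

As far as these compounds go, how a butyl or hexyl chain on that branch would read remains open. So does the effect of an amine or a carboxylic acid here.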